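The compounds below may be only part of what the source reports. "The series", "measured", "known", "first", "only" and "open" are said of these compounds alone.

In a functional assay on 143B cells (Homo sapiens) for inhibition, read by CCK-8 assay, with a stated time of 72 h, tested at 1 uM (a higher number here means more inhibition at the concentration tested (going by the name of the read-out), a lower number less inhibition), compound 2 `Cc1cccc(N2C(=O)CSC2c2cccc(C(=O)NCCCCc3ccccc3)c2)c1` gives 71%, the highest of the two numbers measured. Compound 1 `COc1ccc(OC)c(N2C(=O)CSC2c2cccc(C(=O)NCCCCc3ccccc3)c2)c1` gives 2%. For the measured compounds named here, the only measured step, a number 69 percentage points higher from compound 1 to compound 2 (beyond the scatter), is large. Compound 3 `COc1cc(F)ccc1N1C(=O)CSC1c1cccc(C(=O)NCCCCc2ccccc2)c1` differs from compound 2 by 4-fluoro-2-methoxyphenyl in place of 3-methylphenyl on an amide-type nitrogen in a ring. That single step bears on it: compound 3 again carries a methoxy on the ring, as did compound 1, which gave 2%. A drop beyond the scatter is therefore expected, roughly a number 46 percentage points lower from compound 2 to compound 3 (beyond the scatter). Compound 3 is expected to give 25%, with a range from 3% to 60%.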

Compound 3, a percentage reported as inhibition, at one concentration (the size of the read-out at that concentration, not a potency): 63%
Beside the measured number, compound 3's estimate is 38 percentage points below it, and the stated range ends below it.
By their numbers in this assay, from the lowest: compound 1; then compounds 3 and 2 (each within the scatter of the next).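

In this assay, a methoxy on this ring does not by itself decide the outcome: swapping 3-methylphenyl for 4-fluoro-2-methoxyphenyl gives a number 8 percentage points lower from compound 2 to compound 3 (within the scatter) and leaves the inhibition within the scatter. Both rings in the other pair carry methoxy, yet the step is a number 61 percentage points higher from compound 1 to compound 3 (beyond the scatter) at the same amide-type nitrogen, so the full set of groups on the ring matters here. Nothing available explains this difference.

From the compounds shown here alone, it remains open whether the fluorine or the methoxy arrangement separates these two rings. Going by these compounds, it is also open whether a phenyl ring carrying an amine or a carboxylic acid would keep this inhibition.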